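This account rests on a few compounds, and the source may have more. Where it says the series, first, only, none or still open, it means among the compounds named here.

Three compounds of the series have numbers in a functional assay on Huh-7 cells (Homo sapiens) for antiproliferative activity, read by sulforhodamine B assay, with a stated time of 72 h; a lower number here means a stronger inhibitor, a higher number a weaker inhibitor. Compound 1 `FC(F)(F)c1ccc(CN2CCN(Cc3cc(-c4ccc(OCc5cccc(Cl)c5)cc4)on3)CC2)cc1` gives 200 nM. Compound 2 `N#Cc1cccc(COc2ccc(-c3cc(CN4CCN(Cc5ccc(C(F)(F)F)cc5)CC4)no3)cc2)c1` gives 100 nM, the lowest of the three, and compound 3 `N#Cc1cccc(COc2ccc(-c3cc(CN4CCN(c5ccc(C(F)(F)F)cc5)CC4)no3)cc2)c1` gives 2200 nM. The step of a 2.0-fold lower number from compound 1 to compound 2 (0.30 log units; within the scatter) stays within the scatter, whereas the step of a 22-fold higher number from compound 2 to compound 3 (1.34 log units; beyond the scatter) lies beyond it, so compound 2 is set apart clearly only from compound 3. Compound 4 `Cc1cc(OCc2cccc(C#N)c2)ccc1-c1cc(CN2CCN(Cc3ccc(C(F)(F)F)cc3)CC2)no1` differs from compound 2 by methyl in place of hydrogen on an aromatic carbon. Neither measured step bears on this change: one exchanges chloro for cyano, the other replaces a benzyl with a phenyl on the ring nitrogen. Nothing in the data points to a step beyond the scatter in this assay for an added methyl. For compound 4 the expected value is 120 nM (range 40 nM to 400 nM), a step of a 1.2-fold higher number from compound 2 to compound 4 (0.08 log units; within the scatter) that is expected to stay within the scatter.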

Compound 4, half-maximal inhibitory concentration: 1500 nM
The estimate for compound 4 lay 13-fold (1.10 log units) below the measured number; measured number above the stated range.
By their numbers in this assay, from the lowest: compounds 2 and 1 (each within the scatter of the next); then compounds 4 and 3 (each within the scatter of the next).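

In this assay, the aromatic carbon ortho to a large group and meta to the (3-cyanobenzyl)oxy group proves sensitive: adding one methyl there gives a 15-fold higher number from compound 2 to compound 4 (1.18 log units; beyond the scatter), a large step. The earlier compounds shown here varied only the chloro or cyano substituent and the group on the ring nitrogen, so this ring position was untested until now. No available evidence accounts for the size of this step.

Open, going by these compounds, is whether a fluorine or a methoxy group on this carbon would give a comparable step, and whether a methyl elsewhere on this ring would do the same.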